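Branching the pentyloxy chain of compound 1

The source may hold more compounds than are shown below. What is called first, only, known or untested is meant among the compounds shown, and "the series" means these compounds.

Compound 1 `CCCCCOc1cccc2ccc(N)nc12`: 580 nM
Compound 2 `COC(C)(C)CCOc1cccc2ccc(N)nc12`: 132 nM
Compound 3 `CC(CC(C)(C)C)Oc1cccc2ccc(N(C)C)nc12`: > 2000 nM

In an assay on cells with melanin-concentrating hormone receptor 1 (Homo sapiens) as the target, read by radioligand binding (a lower number here means a stronger inhibitor, a higher number a weaker inhibitor), compound 1 gives the highest of the two numbers; compound 2 sits a 4.4-fold lower number from compound 1 to compound 2 (0.64 log units; beyond the scatter). For compound 3 this assay reports only a limit, (the limit of > 2000 nM in this assay, at which 1 of the 3 values shown sits). Compound 4 `CC(C)C(C)Oc1cccc2ccc(N)nc12` carries 1,2-dimethylpropyl in place of pentyl on an oxygen on an aromatic ring. Among the measured compounds shown here, no measured step covers this change: the step from compound 1 to compound 2 alters the chain in a different way, and compound 3 differs from compound 4 in two places, so its limit cannot be traced to the branching alone. Compound 4 is therefore expected to land near compound 1, a 1.0-fold higher number from compound 1 to compound 4 (0.01 log units; within the scatter), giving an estimated 600 nM with a range from 200 nM to 1800 nM.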

Compound 4, half-maximal inhibitory concentration: 199 nM
For compound 4 the middle estimate is 3.0-fold (0.48 log units) above the measured one; measured number outside the range, below it.
By their numbers in this assay, from the lowest: compounds 2 and 4 (each within the scatter of the next); then compound 1. At a limit, above all of these: compound 3.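

In this assay, putting 1,2-dimethylpropyl in place of pentyl on the oxygen gives a 2.9-fold lower number from compound 1 to compound 4 (0.46 log units; beyond the scatter) with no change in the atoms present. The arrangement of the chain alone therefore moves the number beyond the scatter, which the step to compound 2 could not show, since that change also brought in a methoxy oxygen. Nothing given here explains the step. Compound 3 differs from compound 4 in two places, so it cannot show how far branching can go. As far as these compounds go, how a longer branched chain, or an amine at the chain end, would fare remains open.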